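A few compounds are considered here, and "the series" means these few. Any claim that something is new, unique, unknown or untested is made for them only; others in the source may bear on it.

Three compounds share one core and differ only in the group carried on the sulfonamide nitrogen; the measure is a functional assay on M21 cells (Homo sapiens) for antiproliferative activity, read by sulforhodamine B assay, with a stated time of 48 h; a higher number here means a weaker inhibitor, a lower number a stronger inhibitor. Compound 1 `CC(C)Cc1ccc(NS(=O)(=O)c2ccc(N3CCNC3=O)cc2)cc1` carries an isobutyl group, and in this assay compound 1 gives only a limit, > 1000 nM. Compound 2 `O=C1NCCN1c1ccc(S(=O)(=O)Nc2ccc(C3CCCCC3)cc2)cc1` carries a cyclohexyl group, and in this assay compound 2 likewise gives only a limit, > 1000 nM. Among the measured compounds shown here, compound 3 `O=C1NCCN1c1ccc(S(=O)(=O)Nc2ccc(Br)cc2)cc1` carries a bromo group and is the one compound with a number in this assay, where compound 3 gives 130 nM. Compound 1 and compound 2 sit at a limit of the assay, as noted in the limit of > 1000 nM in this assay, at which 2 of the 3 values shown sit. The step of an at least 7.6-fold lower number from compound 1 to compound 3 (0.88 log units; beyond the scatter) and the step of an at least 7.6-fold lower number from compound 2 to compound 3 (0.88 log units; beyond the scatter) both point the same way, while the step that the two limits leave unreadable from compound 1 to compound 2 cannot be read.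

Compound 4 `Cc1ccc(NS(=O)(=O)c2ccc(N3CCNC3=O)cc2)cc1C` is not yet measured. It differs from compound 3 in one place: 3,4-dimethylphenyl in place of 4-bromophenyl on a sulfonamide nitrogen. The two steps that bear on this change both show that isobutyl or cyclohexyl in this position gives a weaker inhibitor than bromo, so a step in that direction is expected, though 3,4-dimethylphenyl is neither of those groups and the size of the step is uncertain. The expected step is a 3.1-fold higher number from compound 3 to compound 4 (0.49 log units; beyond the scatter), and in this assay compound 4 is estimated at 400 nM, within 130 nM to 2000 nM.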

Compound 4, half-maximal inhibitory concentration: 94 nM
For compound 4 the middle estimate is 4.3-fold (0.63 log units) above the measured one; the measured number lies below the stated range.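

Swapping 4-bromophenyl for 3,4-dimethylphenyl on the sulfonamide nitrogen gives a 1.4-fold lower number from compound 3 to compound 4 (0.14 log units; within the scatter), so in this assay the two compounds cannot be told apart. Among the compounds shown here, until now, bromo was the only group at this position with a number rather than a limit, and the two groups built from carbon alone, isobutyl and cyclohexyl, had both given limits; that left open whether bromine itself was needed for a value in this range. The new result shows that it is not: a ring carrying only carbon substituents, with no bromine at all, also gives a measurable value here, so having carbon groups on this ring does not by itself push a compound to the limit.

How far compound 1 and compound 2 really fall short of the others stays unknown, and no size can be given for their steps because their values are not numbers: the limit of > 1000 nM in this assay, at which 2 of the 4 values shown sit. The compounds shown also leave open whether a single methyl group would serve as well as two, and what an amine or a carboxylic acid on this ring would do.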